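From Hexylcarbamoyl to Carboxy in a Growth Assay

The source may report more compounds than this note shows. Statements on the series, on what has been measured and on what is new or still open speak of the compounds shown alone.

Compound 1 `CCCCCCNC(=O)c1cc(C#Cc2cc(OC)ccc2OC)ccc1OC` gives > 100000 nM in a functional assay on SF-539 cells (Homo sapiens) for antiproliferative activity (a higher number here means a weaker inhibitor of growth, a lower number a stronger inhibitor of growth), and this is a limit of the assay, not a number. Going by the values given here, on the numbers so far, compound 1 stands at the limit of > 100000 nM in this assay, at which 1 of the 2 values shown sits. Compound 2 `CCCCCCNC(=O)c1cc(/C=C\c2cc(O)ccc2O)ccc1O` differs from it in more than one place and gives a measured 3300 nM, so the series can register growth inhibition.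

Compound 3 `COc1ccc(OC)c(C#Cc2ccc(OC)c(C(=O)O)c2)c1` keeps the core of compound 1 and changes one place: hydroxy in place of hexylamino on a carbonyl carbon. In words, hydroxy replaces hexylamino on a carbonyl carbon, so hexylcarbamoyl becomes carboxy. Among the compounds with values here, no measured pair of compounds shows what this change does, which leaves compound 1 as the only starting point. Compound 1 stands at the limit of > 100000 nM in this assay, at which 1 of the 2 values shown sits, so no gain in this assay beyond the scatter is expected, and compound 3 may well return only a limit too. The expected size of the change is a number no higher from compound 1 to compound 3 (the limit leaves the size open), which is no real step in either direction. Compound 3 is estimated at 100000 nM, with an expected range of 30000 nM to 300000 nM.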

Compound 3, concentration for 50% growth inhibition: 38500 nM
For compound 3 the middle estimate is 2.6-fold (0.41 log units) above the measured one; measured number inside the range.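

In this assay, putting hydroxy in place of hexylamino on the carbonyl carbon gives an at least 2.5-fold lower number from compound 1 to compound 3 (0.41 log units; beyond the scatter), so this position does respond to a change and the hexylcarbamoyl group is not required for a measurable effect on the core of compound 1. Compound 3 gives 38500 nM, which makes it the only compound shown on that core with a real number, and so a firmer point of comparison for any further change at this position. Compound 1 stands at a limit of the assay and not at a number, so the true size of the step stays open: the limit of > 100000 nM in this assay, at which 1 of the 3 values shown sits.

As far as these compounds go, it also stays open whether the gain comes from losing the hexyl chain or from gaining the carboxy group, and a shorter chain on the same amide, such as methylamino, or a methyl ester on the same carbonyl carbon, would begin to separate the two. Nor can this step be read against compound 2, which gives 3300 nM but differs from compound 3 in more than one place.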